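Compound 4: aryl change on a weak compound

The source may report more compounds than this note shows. Statements on the series, on what has been measured and on what is new or still open speak of the compounds shown alone.

In a functional assay on M21 cells (Homo sapiens) for antiproliferative activity, read by sulforhodamine B assay, with a stated time of 48 h (on this read-out higher numbers stand for weaker inhibition and lower numbers for stronger inhibition), compound 3 (`CCCN1CCN(c2ccc(S(=O)(=O)Oc3ccccc3CC)cc2)C1=O`) gives > 50000 nM, which is a limit and not a number. It stands at the limit of > 50000 nM in this assay, at which 1 of the 3 values shown sits. Compound 1 (`CCc1ccccc1OS(=O)(=O)c1ccc(N2CCN(C)C2=O)cc1`) gives 2300 nM, and compound 2 (`COc1cccc(OS(=O)(=O)c2ccc(N3CCN(C)C3=O)cc2)c1`) gives 1600 nM.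

Compound 4 (`CCCN1CCN(c2ccc(S(=O)(=O)Oc3cccc(F)c3)cc2)C1=O`) differs from compound 3 by 3-fluorophenyl in place of 2-ethylphenyl on an oxygen, with 3-fluorophenyl in place of 2-ethylphenyl on an oxygen. For the measured compounds named here, the one measured aryl change is a 1.4-fold lower number from compound 1 to compound 2 (0.16 log units; within the scatter). The large step is an at least 21-fold higher number from compound 1 to compound 3 (1.33 log units; beyond the scatter), a chain change that compound 4 retains. No step beyond the scatter is thus expected in this assay. The estimated step is an at least 1.2-fold lower number from compound 3 to compound 4 (0.09 log units; that floor lies within the scatter). Compound 4 is expected at 40000 nM, with an estimated range of 15000 nM to 70000 nM.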

Compound 4, half-maximal inhibitory concentration: 12000 nM
For compound 4 the middle estimate is 3.3-fold (0.52 log units) above the measured one; the whole stated range lies above it.
By their numbers in this assay, from the lowest: compounds 2 and 1 (each within the scatter of the next); then compound 4. At a limit, above all of these: compound 3.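

With the chain of compound 3 kept, the aryl group on the oxygen is not silent in this assay: the 3-fluorophenyl change gives an at least 4.1-fold lower number from compound 3 to compound 4 (0.61 log units; beyond the scatter). The earlier aryl change, 3-methoxyphenyl in place of 2-ethylphenyl, gave a 1.4-fold lower number from compound 1 to compound 2 (0.16 log units; within the scatter). That newer step is only a floor, since compound 3 stands at a limit: the limit of > 50000 nM in this assay, at which 1 of the 4 values shown sits.

Still open, on these data alone, is what 3-fluorophenyl does on the shorter chain of compound 1. Also open, as far as these compounds go, is how an amine or a carboxylic acid on that aryl ring would read on the chain of compound 4.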